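Adding hydroxy and methoxy to the benzoyl phenyl of compound 2

A few compounds are considered here, and "the series" means these few. Any claim that something is new, unique, unknown or untested is made for them only; others in the source may bear on it.

In a functional assay on HCT-116 cells (Homo sapiens) for inhibition, read by MTT assay, with a stated time of 48 h (a lower number here means a stronger inhibitor, a higher number a weaker inhibitor), compound 1 (`COc1cc(-c2nnc(S)n2-c2ccc(N(C)C)cc2)cc(OC)c1OC`) gives > 60000 nM, which is a limit of the assay and not a number. Among the measured compounds shown here, compound 2 (`COc1cc(-c2nnc(SCC(=O)c3ccccc3)n2-c2ccc(N(C)C)cc2)cc(OC)c1OC`) gives 42500 nM, the only actual number so far. For the measured compounds named here, the single measured step, an at least 1.4-fold lower number from compound 1 to compound 2 (0.14 log units; that floor lies within the scatter), placed benzoylmethyl on a sulfur, and its floor lies within the scatter, so it establishes no firm gain. Compound 3 (`COc1ccc(C(=O)CSc2nnc(-c3cc(OC)c(OC)c(OC)c3)n2-c2ccc(N(C)C)cc2)cc1O`) differs from compound 2 by 3-hydroxy-4-methoxyphenyl in place of phenyl on a carbonyl carbon. Going by the values given here, no measured step touches this phenyl, so the data give only weak guidance on size. Compound 2, at 42500 nM, is a weak inhibitor, so any clear movement is expected toward a lower number. The expected change is an 11-fold lower number from compound 2 to compound 3 (1.03 log units; beyond the scatter), an uncertain estimate. For compound 3, the estimated value is 4000 nM, with an expected range of 100 nM to 60000 nM.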

Compound 3, half-maximal inhibitory concentration: > 100000 nM
Compound 3 gave a limit, no number; the forecaster's own chance of this, stated with the estimate: 12%; middle value at least 25-fold (1.39 log units) away from the limit.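

The phenyl on the carbonyl carbon does not tolerate every change: placing 3-hydroxy-4-methoxyphenyl there gives an at least 2.3-fold higher number from compound 2 to compound 3 (0.37 log units; beyond the scatter) in this assay, the first step among these compounds that lies beyond the scatter. For compound 3 the reading is a limit and not a number, so this step gives only a minimum size: the limit of > 100000 nM in this assay, at which 1 of the 3 values shown sits. The step between the thiol compound and compound 3 cannot be read, as both of its ends are limits.

Compound 3 carries the hydroxy and the methoxy together, and the compounds shown leave open whether either group alone would give the same loss. Also open, as far as these compounds go, is whether a single fluorine or a dimethylamino group on this phenyl would move the number below that of compound 2.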